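The source may hold more compounds than are shown below. What is called first, only, known or untested is meant among the compounds shown, and "the series" means these compounds.

Measured in an ADME assay on microsomes from liver (Mus musculus) for metabolic stability; a lower number here means that the compound disappears faster, a higher number that the compound lasts longer:
- compound 1 `CC(C)C(Cc1nnc[nH]1)c1ccc(-c2ccc3cccc(F)c3c2)[nH]c1=O`: < 0.0667 h (a limit)
- compound 2 `CCn1ncc2c(F)cc(-c3ccc(C(CC)(CC)c4nncn4C)c(=O)[nH]3)cc21`: > 3 h (a limit)

Neither result is an exact number. Compound 1 sits at the short end of the two results, with the limit of < 0.0667 h in this assay, at which 1 of the 2 values shown sits. Compound 2 sits at the long end, with the limit of > 3 h in this assay, at which 1 of the 2 values shown sits.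

Compound 3 `CC(C)C(c1cnc(N)s1)c1ccc(-c2ccc3cccc(F)c3c2)[nH]c1=O` is the next case. It keeps the core of compound 1 and carries 2-amino-1,3-thiazol-5-yl in place of (4H-1,2,4-triazol-3-yl)methyl on a saturated chain carbon bound to an aromatic carbon and a saturated chain carbon.

For the measured compounds named here, no measured pair of compounds shows what this exchange does in this assay, so the starting point is compound 1 alone. With the rest of the structure unchanged, no step beyond the scatter is expected, in either direction. The estimated move is an at least 1.1-fold higher number from compound 1 to compound 3 (0.07 log units; that floor lies within the scatter). A result reported only as a limit would be no surprise. For compound 3 the expected half-life is 0.08 h, with an estimated range of 0.03 h to 0.3 h.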

Compound 3, half-life: 0.08 h
Estimate against measurement, compound 3: no gap at the digits printed; the range from low to high includes it.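

In this assay, putting 2-amino-1,3-thiazol-5-yl in place of (4H-1,2,4-triazol-3-yl)methyl on a saturated chain carbon bound to an aromatic carbon and a saturated chain carbon gives an at least 1.1-fold higher number from compound 1 to compound 3 (0.07 log units; that floor lies within the scatter), so this exchange shows no step beyond the scatter. With compound 3 at 0.08 h, the core of compound 1 now has an exact half-life with a group at this place. Neither of the earlier results provided an exact number. Going by these compounds, the step can be read only as a floor, and its full size stays unknown, because compound 1 is reported as a limit and not as a number: the limit of < 0.0667 h in this assay, at which 1 of the 3 values shown sits.

The compounds shown leave open whether any group at this place can lift the half-life on this core, for instance a carboxylic acid, a simple amine or a longer chain ending in the same 2-amino-1,3-thiazol-5-yl. Compound 2 differs from compound 1 and compound 3 in more than one place, so it cannot tell which of its differences goes with its own limit in this assay.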